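A few compounds are considered here, and "the series" means these few. Any claim that something is new, unique, unknown or untested is made for them only; others in the source may bear on it.

Measured in a physicochemical assay for solubility, read by nephelometry, in phosphate buffer, measured as kinetic solubility, at pH 6.5; on this read-out higher numbers stand for higher solubility and lower numbers for lower solubility:
- compound 1 `CC1=C(C(=O)OC(C)(C)C)C(=O)/C(=C\c2cc(C)n(-c3ccccc3C(F)(F)F)c2C)N1`: 1.6 ug/mL
- compound 2 `CC1=C(C(=O)OCc2ccccc2)C(=O)/C(=C\c2cc(C)n(-c3ccccc3C(F)(F)F)c2C)N1`: < 1.6 ug/mL (a limit, not a number)
- compound 3 `CC1=C(C(=O)O)C(=O)/C(=C\c2cc(C)n(-c3ccccc3C(F)(F)F)c2C)N1`: 1.6 ug/mL

Level with compound 1, compound 3 stands at 1.6 ug/mL. The next compound to be read is compound 4 `CC1=C(C(N)=O)C(=O)/C(=C\c2cc(C)n(-c3ccccc3C(F)(F)F)c2C)N1`. The change is amino in place of hydroxy on a carbonyl carbon, or carboxy to carbamoyl.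

Within the data shown here, no measured step makes this exact exchange, so the nearest guidance comes from steps at the same carbonyl. Only one of these has a readable size: no change at the digits printed from compound 1 to compound 3 (within the scatter), with hydrogen in place of tert-butyl. As far as these compounds go, the other two, a number no higher from compound 1 to compound 2 (the limit leaves the size open) and a number no lower from compound 2 to compound 3 (the limit leaves the size open), give direction at most, and their size stays open. On that thin basis, with compound 1 and compound 3 level, no step beyond the scatter is expected in this assay, and no direction is favoured. The expected step is no change at the digits printed from compound 3 to compound 4 (within the scatter). A report of a limit for compound 4 is a real possibility, given (the limit of < 1.6 ug/mL in this assay, at which 1 of the 3 values shown sits).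

For compound 4 the estimated value is 1.6 ug/mL, with an expected range of 0.8 ug/mL to 3.5 ug/mL.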

Compound 4, solubility: 6.3 ug/mL
Beside the measured number, compound 4's estimate is 3.9-fold (0.60 log units) below it; the whole stated range lies below it.
By their numbers in this assay, from the lowest: compounds 1 and 3 (each within the scatter of the next); then compound 4.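

Among these compounds, on the carbonyl carbon whose other neighbour is the double-bonded ring carbon, this assay now shows a step beyond the scatter, which the readable step among the earlier compounds did not: amino in place of hydroxy gives a 3.9-fold higher number from compound 3 to compound 4 (0.60 log units; beyond the scatter), and amino in place of tert-butoxy gives a 3.9-fold higher number from compound 1 to compound 4 (0.60 log units; beyond the scatter). Amino in place of benzyloxy gives an at least 3.9-fold higher number from compound 2 to compound 4 (0.59 log units; beyond the scatter), so within these compounds the carbamoyl group stands apart from all three other groups on this carbonyl carbon. Compound 2 holds a limit and not a number, so the size of that last step stays open at its upper end: the limit of < 1.6 ug/mL in this assay, at which 1 of the 4 values shown sits.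

As far as these compounds go, whether the step belongs to the carbamoyl group itself or extends to substituted amides stays open, and a methylamide or a dimethylamide in place of the carbamoyl group would bear on that. The exchange is also shown on a single core only, so it remains open whether hydroxy to amino gives a similar step when the trifluoromethyl group is replaced by, for example, a chloro or methoxy group.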